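The source may hold more compounds than are shown below. What is called first, only, known or untested is meant among the compounds shown, and "the series" means these compounds.

Compound 2 `CC1=CC[C@@H]([C@@](C)(O)CCCC(C)(C)NC(=S)N/N=C\c2ccc(N(C)C)cc2)CC1` bears a 4-(dimethylamino)phenyl group on a carbon with a double bond to nitrogen. In a functional assay on OVCAR-3 cells (Homo sapiens) for cytotoxicity, read by sulforhodamine B assay (on this read-out higher numbers stand for lower toxicity in this test and lower numbers for higher toxicity in this test), compound 2 reaches only a limit of the assay, > 100000 nM. Its nearest measured neighbour, compound 1 `CC1=CC[C@@H]([C@@](C)(O)CCCC(C)(C)NC(=S)N/N=C\c2ccc(C)cc2)CC1`, gives 45300 nM in this assay. Among the measured compounds shown here, the single measured step, an at least 2.2-fold higher number from compound 1 to compound 2 (0.34 log units; beyond the scatter), ends at the limit of > 100000 nM in this assay, at which 1 of the 2 values shown sits. Compound 3 `CC1=CC[C@@H]([C@@](C)(O)CCCC(C)(C)NC(=S)N/N=C\c2cccc([N+](=O)[O-])c2)CC1` differs from compound 2 by 3-nitrophenyl in place of 4-(dimethylamino)phenyl on a carbon with a double bond to nitrogen. For the measured compounds named here, no measured step involves a nitro group, so the size of this change in this assay is uncertain. The expected step is an at least 2.0-fold lower number from compound 2 to compound 3 (0.30 log units; that floor lies within the scatter). Compound 3 is expected to give about 50000 nM, within 15000 nM to 150000 nM.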

Compound 3, concentration lethal to 50% of the cells: > 100000 nM
Compound 3: no number, only a limit (the forecaster's own chance of this, stated with the estimate: 40%); at least 2.0-fold (0.30 log units) between middle value and limit.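

In this assay, 3-nitrophenyl in place of 4-methylphenyl on this carbon gives an at least 2.2-fold higher number from compound 1 to compound 3 (0.34 log units; beyond the scatter), so the 4-(dimethylamino)phenyl group of compound 2 is no longer the only replacement to give this result. The step between compound 2 and compound 3 cannot be read, since neither compound has a number, only a limit. Most of the values shown now sit at that same limit: the limit of > 100000 nM in this assay, at which 2 of the 3 values shown sit.

On these data alone, it remains open how compound 2 and compound 3 truly rank. As far as these compounds go, it is also open whether a carboxylic acid in place of the nitro group would give a number within the range of the assay.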